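From thiophen-2-yl to thiophen-3-yl on a shared core

The source may report more compounds than this note shows. Statements on the series, on what has been measured and on what is new or still open speak of the compounds shown alone.

Compound 1 `CNc1ncnc2c1c(-c1ccsc1)cn2[C@@H]1O[C@H](CO)[C@@H](O)[C@H]1O` gives > 20000 nM as a limit
Compound 2 `Cc1ncnc2c1c(-c1ccoc1)cn2[C@@H]1O[C@H](CO)[C@@H](O)[C@H]1O` gives > 15000 nM as a limit
Compound 3 `Cc1ncnc2c1c(-c1cccs1)cn2[C@@H]1O[C@H](CO)[C@@H](O)[C@H]1O` gives 5730 nM as a number

In a functional assay on HL-60 cells (Homo sapiens) for antiproliferative activity, read by XTT assay, with a stated time of 72 h (a lower number here means a stronger inhibitor, a higher number a weaker inhibitor), compound 3 gives 5730 nM and is the only one of the three with an actual number. The values of compound 1 and compound 2 are limits. Compound 4 `Cc1ncnc2c1c(-c1ccsc1)cn2[C@@H]1O[C@H](CO)[C@@H](O)[C@H]1O` carries thiophen-3-yl in place of thiophen-2-yl on an aromatic carbon of the shared core, thiophen-3-yl in place of thiophen-2-yl on an aromatic carbon and the two have the same atoms, joined differently.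

Among the measured compounds shown here, one measured step bears on this place. It is an at least 2.6-fold lower number from compound 2 to compound 3 (0.41 log units; beyond the scatter) and it lies beyond the scatter, though it changes the ring as well as its point of attachment and starts from a limit. Like compound 4, compound 1 bears thiophen-3-yl, and compound 1 gives > 20000 nM as a limit, on a core that is not quite the same.

With so little to go on, a step toward a higher number in this assay is expected, of a size near the scatter. The estimated step is a 1.7-fold higher number from compound 3 to compound 4 (0.24 log units; within the scatter) on this reading. For compound 4 the expected value is 10000 nM with an estimated range from 3000 nM to 30000 nM around it.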

Compound 4, half-maximal inhibitory concentration: 350 nM
Compound 4: the middle estimate sits 29-fold (1.46 log units) above what was measured; measured number below the stated range.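

In this assay, changing only the point of attachment of the thiophene ring on the shared core gives a 16-fold lower number from compound 3 to compound 4 (1.21 log units; beyond the scatter), so the attachment alone carries a large effect here, which the earlier step could not show because it changed the ring as well. With the attachment held, thiophen-3-yl in place of furan-3-yl gives an at least 42-fold lower number from compound 2 to compound 4 (1.63 log units; beyond the scatter), and this size is only a bound, as compound 2 has a limit and not a number: the limit of > 15000 nM in this assay, at which 1 of the 4 values shown sits. Thiophen-3-yl alone does not secure the result, since methyl in place of methylamino on the other aromatic carbon gives an at least 57-fold lower number from compound 1 to compound 4 (1.75 log units; beyond the scatter), again only a bound, as compound 1 also has a limit and not a number: the limit of > 20000 nM in this assay, at which 1 of the 4 values shown sits.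

The compounds shown leave open whether a furan-2-yl or phenyl ring at this place would keep the number of compound 4 or lose it. They also leave open whether an ethyl or a plain amino group could stand in for the methyl, and they offer no explanation for the gap between the two thiophene attachments.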